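A double bond added to the chain of compound 1

The source may report more compounds than this note shows. Statements on the series, on what has been measured and on what is new or still open speak of the compounds shown alone.

In a functional assay on MCF7 cells (Homo sapiens) for antiproliferative activity, read by MTT assay (on this read-out lower numbers stand for stronger inhibition and higher numbers for weaker inhibition), compound 1 (`CCCCC/C=C\C/C=C\CCCCCCCc1cc(=O)c2c(O)c(C)c(OCOC)c(C)c2o1`) gives > 84100 nM and so stands at the limit of > 84100 nM in this assay, at which 1 of the 3 values shown sits, which is a limit of the assay and not a number.

Compound 4 (`CC/C=C\C/C=C\C/C=C\CCCCCCCc1cc(=O)c2c(O)c(C)c(OCOC)c(C)c2o1`) keeps the core of compound 1 and changes only the chain. but-1-en-1-yl in place of butyl on a saturated chain carbon bound to a double-bonded chain carbon sums up the change: but-1-en-1-yl in place of butyl on a saturated chain carbon bound to a double-bonded chain carbon.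

The same chain as in compound 4 occurs in compound 2 (`CC/C=C\C/C=C\C/C=C\CCCCCCCc1cc(=O)c2c(O)cc(O)cc2o1`) on a different core, and compound 2 gives 17500 nM in this assay. Compound 3 (`CCCC/C=C/CCCCCCCCCC1(O)CC(=O)C2=C(O)C(C)C(O)C(C)=C2O1`), with another chain and another core, gives 17500 nM there. Neither compound isolates the effect of this chain change, so the evidence is thin.

For the measured compounds named here, only a small move towards stronger inhibition is expected, with no step clearly beyond the usual scatter. The estimated at least 1.2-fold lower number from compound 1 to compound 4 (0.11 log units; that floor lies within the scatter) is correspondingly modest. For compound 4 the estimated value is 65000 nM, with an expected range from 25000 nM to 130000 nM.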

Compound 4, half-maximal inhibitory concentration: > 84100 nM
Compound 4: only a limit was reported; the forecaster's own chance of this, stated with the estimate: 55%; middle value at least 1.2-fold (0.11 log units) from the limit.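

In this assay compound 4 gives > 84100 nM, which is a limit of the assay and not a number. For the compounds shown here, compound 1 also stands at a limit, so no step from compound 1 to compound 4 can be read: the limit of > 84100 nM in this assay, at which 2 of the 4 values shown sit. As far as these compounds go, whether but-1-en-1-yl in place of butyl changes the inhibition at all stays open.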